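Chain length at the para position of aryl acrylic acids

The source may report more compounds than this note shows. Statements on the series, on what has been measured and on what is new or still open speak of the compounds shown alone.

Measured compounds:
compound 1, `CC(C)c1ccc(C(=O)/C=C/C(=O)O)c(C(C)C)c1`: 4680 nM
compound 2, `CCc1ccc(C(=O)/C=C/C(=O)O)cc1`: 5530 nM

The two measured compounds share a core in which an aromatic ring carries an acryloyl acid side chain. In a functional assay on K562 cells (Homo sapiens) for inhibition, read by MTT assay, with a stated time of 72 h (a lower number here means a stronger inhibitor, a higher number a weaker inhibitor), compound 1 gives 4680 nM. In this assay compound 2 gives 5530 nM, the higher of the two numbers, though its gap to compound 1 lies within the scatter, so the two compounds cannot be told apart on these data.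

Compound 3, `CCCCc1ccc(C(=O)/C=C/C(=O)O)cc1`, has not yet been measured in this assay. It differs from compound 2 in one place: ethyl in place of hydrogen on a saturated chain carbon, two bonds along the chain from an aromatic carbon. Going by the values given here, with no step between measured compounds available, the size of the change can only be guessed. Compound 3 is expected to show a 1.4-fold lower number from compound 2 to compound 3 (0.14 log units; within the scatter), a small shift toward a lower number that may not exceed the scatter. Compound 3 is estimated at 4000 nM, within 1500 nM to 10000 nM.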

Compound 3, half-maximal inhibitory concentration: 4950 nM
The estimate for compound 3 lay 1.2-fold (0.09 log units) below the measured number, and the stated range covers the measured number.
By their numbers in this assay, from the lowest: compounds 1, 3 and 2 (each within the scatter of the next).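

In this assay, going by these compounds alone, the exchange of ethyl for butyl on the shared core gives a 1.1-fold lower number from compound 2 to compound 3 (0.05 log units; within the scatter), and this is the first comparison here of two compounds that differ in one place. At this position, therefore, ethyl in place of hydrogen on a saturated chain carbon, two bonds along the chain from an aromatic carbon, produces no difference that can be told apart from the scatter. Nothing available here bears on why the step is this small. Going by these compounds, whether a longer chain such as hexyl, or an amine or a hydroxyl group at the end of the butyl chain, would shift the number remains open. Also open, on these data alone, is whether the same step would stay this small if an amide took the place of the carboxylic acid.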